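The compounds below may be only part of what the source reports. "The series", "measured", "known", "first", "only" and "open" are said of these compounds alone.

Three compounds have been measured so far in a physicochemical assay for solubility, in phosphate buffer, with a stated time of 18 h, at pH 7.4 (on this read-out higher numbers stand for higher solubility and lower numbers for lower solubility), and read as follows:

- Compound 1 `Nc1nc(-c2ccccc2)nn1-c1ncnc2ccccc12` gives 1000 nM
- Compound 2 `COc1cc2nc(-c3ccccc3)nc(-n3nc(-c4ccccn4)nc3N)c2cc1OC` gives 2000 nM
- Compound 3 `COc1cc2ncnc(-n3nc(-c4ccccn4)nc3N)c2cc1OCc1ccccc1` gives 58000 nM

Compound 3 holds the highest of the three numbers. Its gaps to compound 2 and to compound 1 both lie beyond the usual scatter, and the gap to compound 1 is the wider.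

The next compound is compound 4 `COc1cc2ncnc(-n3nc(-c4ccccn4)nc3N)c2cc1OCCCCNC(=O)OC(C)(C)C`, which departs from compound 3 at one place: 3-((tert-butoxycarbonyl)amino)propyl in place of phenyl on a saturated chain carbon bound to an oxygen on an aromatic ring. In words, 3-((tert-butoxycarbonyl)amino)propyl stands in place of phenyl on a saturated chain carbon bound to an oxygen on an aromatic ring. Cut one bond further out, the same difference reads benzyl to 4-((tert-butoxycarbonyl)amino)butyl.

Among the compounds with values here, no two measured compounds differ at only one place, so nothing measured fixes the size of this change. Compound 3 at 58000 nM already tops the series, so a fall seems likelier than a further rise. The expected change in this assay is therefore a modest drop near the edge of the scatter, estimated as a 2.3-fold lower number from compound 3 to compound 4 (0.37 log units; beyond the scatter) on this read-out. The estimate for compound 4 is 25000 nM with an expected range from 6000 nM to 80000 nM on the same read-out.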

Compound 4, solubility: 500 nM
Beside the measured number, compound 4's estimate is 50-fold (1.70 log units) above it, outside the stated range (below it).
By their numbers in this assay, from the lowest: compounds 4, 1 and 2 (each within the scatter of the next, the first and the last beyond it); then compound 3.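

The exchange of phenyl for 3-((tert-butoxycarbonyl)amino)propyl, on a saturated chain carbon bound to an oxygen on an aromatic ring, supplies the first measured size for any single change in this series: in this assay it gives a 120-fold lower number from compound 3 to compound 4 (2.06 log units; beyond the scatter) and counts as a large step. This shows that the read-out is far from indifferent to what this position carries. The high number of compound 3 therefore cannot be credited to the shared core alone, since compound 4 keeps that core and loses most of the number. Nothing else measured here speaks to what lies behind the size of this step.

With a single step at this position, the compounds shown cannot separate the loss of the phenyl ring from the arrival of the chain and its tert-butoxycarbonyl group. A plain butyl chain, a free primary amine at the end of the same chain, a carboxylic acid there or a longer chain would each leave open how much of the fall belongs to which part.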